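Urea Analogue with a Different Benzyl Group

This account rests on a few compounds, and the source may have more. Where it says the series, first, only, none or still open, it means among the compounds named here.

Compound 3 `Cc1ccc(NC(=O)NC(=O)c2ccc(OCc3cccc(C(F)(F)F)c3)cc2)cc1-c1nc2ccccc2[nH]1` gives 3520 nM in a functional assay on HT-29 cells (Homo sapiens) for inhibition, read by MTT assay, with a stated time of 48 h (a higher number here means a weaker inhibitor, a lower number a stronger inhibitor), the lowest of the three numbers in hand. Compound 1 `Cc1ccc(NC(=S)NC(=O)c2ccc(OCc3cccc(C(F)(F)F)c3)cc2)cc1-c1nc2ccccc2[nH]1` gives 8200 nM and compound 2 `Cc1ccc(NC(=S)NC(=O)c2ccc(OCc3ccc(Cl)cc3Cl)cc2)cc1-c1nc2ccccc2[nH]1` gives 11600 nM in this assay, each above compound 3 by a step beyond the scatter. Compound 4 `Cc1ccc(NC(=O)NC(=O)c2ccc(OCc3ccccc3Cl)cc2)cc1-c1nc2ccccc2[nH]1` has not yet been measured; it differs from compound 3 by 2-chlorophenyl in place of 3-(trifluoromethyl)phenyl on a saturated chain carbon bound to an oxygen on an aromatic ring. For the measured compounds named here, the one measured step that bears on this kind of exchange is a 1.4-fold higher number from compound 1 to compound 2 (0.15 log units; within the scatter), where 2,4-dichlorophenyl took the place of 3-(trifluoromethyl)phenyl on a saturated chain carbon bound to an oxygen on an aromatic ring, and the number stayed within the scatter. Going by the values given here, no measured compound carries a 2-chlorophenyl group, so that single step is the closest guide. On that basis the step from compound 3 to compound 4 is expected to be small, a 1.2-fold higher number from compound 3 to compound 4 (0.08 log units; within the scatter), with no direction beyond the scatter. Compound 4 is therefore estimated at 4200 nM, with a range from 1800 nM to 9500 nM.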

Compound 4, half-maximal inhibitory concentration: 9010 nM
For compound 4 the middle estimate is 2.1-fold (0.33 log units) below the measured one; measured number inside the range.
By their numbers in this assay, from the lowest: compound 3; then compounds 1, 4 and 2 (each within the scatter of the next).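

In this assay, the group on a saturated chain carbon bound to an oxygen on an aromatic ring now makes a difference beyond the scatter, with 2-chlorophenyl in place of 3-(trifluoromethyl)phenyl giving a 2.6-fold higher number from compound 3 to compound 4 (0.41 log units; beyond the scatter) in the carbonyl series. For the compounds shown here, the only earlier exchange at this place, a 1.4-fold higher number from compound 1 to compound 2 (0.15 log units; within the scatter) with 2,4-dichlorophenyl as the entering group, stayed within the scatter, so this place does not tolerate every exchange equally. Nothing measured here accounts for the size of the new step.

On these data alone, it remains open whether the step follows from losing the trifluoromethyl group or from gaining the chlorine, which an unsubstituted phenyl at this place could separate. As far as these compounds go, whether 2-chlorophenyl would give a similar step in the sulfur-bearing compounds also remains open.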